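Swapping the heteroaryl arm of a sulfoxide diphenylmethyl series

This account rests on a few compounds, and the source may have more. Where it says the series, first, only, none or still open, it means among the compounds named here.

Measured so far:
compound 1 `Cc1cc(O)nc(C[S+]([O-])C(c2ccccc2)c2ccccc2)n1` — 109000 nM
compound 2 `[O-][S+](Cc1ccc(Cl)s1)C(c1ccccc1)c1ccccc1` — 12800 nM

Going by the values given here, in an assay on HEK293 cells for inhibition of sodium-dependent dopamine transporter (Homo sapiens), read by scintillation counting, with stated times of 5 min and 1 min (on this read-out higher numbers stand for weaker inhibition and lower numbers for stronger inhibition), compound 2 gives the lower of the two numbers, and the only measured step, an 8.5-fold lower number from compound 1 to compound 2 (0.93 log units; beyond the scatter), is the one that bears on the next change. Compound 3 `[O-][S+](Cc1ccncc1)C(c1ccccc1)c1ccccc1` differs from compound 2 by pyridin-4-yl in place of 5-chlorothiophen-2-yl on a saturated chain carbon bound to a sulfur. Since compound 1 with its six-membered nitrogen heteroaryl gave 109000 nM, a return toward a six-membered nitrogen ring is expected to give a higher number; the step of a 2.7-fold higher number from compound 2 to compound 3 (0.44 log units; beyond the scatter) is the estimate. Compound 3 is therefore expected at 35000 nM, within 12000 nM to 100000 nM.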

Compound 3, half-maximal inhibitory concentration: 63500 nM
Compound 3: middle estimate off by 1.8-fold (0.26 log units), on the low side, within the range that was stated.
By their numbers in this assay, from the lowest: compound 2; then compounds 3 and 1 (each within the scatter of the next).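

Replacing the 5-chlorothiophen-2-yl arm with pyridin-4-yl gives up the advantage seen at this position, with a 5.0-fold higher number from compound 2 to compound 3 (0.70 log units; beyond the scatter), although the heavy-atom and acceptor counts stay the same. The two six-membered nitrogen arms are not told apart, with a 1.7-fold lower number from compound 1 to compound 3 (0.23 log units; within the scatter), so compound 2 alone stands out among the three. Nothing available explains these differences. Going by these compounds, it remains open whether the chlorine or the thiophene ring accounts for the lower number of compound 2. An unsubstituted thiophen-2-yl or a 4-chlorophenyl arm would separate the two.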